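Benzyl Replaced by Tetrahydronaphthalenyl on the Hydroxamate Amide

A few compounds are considered here, and "the series" means these few. Any claim that something is new, unique, unknown or untested is made for them only; others in the source may bear on it.

Measured compounds:
compound 1 `CN(C)c1ccc(C(=O)N[C@@H](CCCCCC(=O)NO)C(=O)NCc2ccccc2)cc1` — 12000 nM
compound 2 `CN(C)c1ccc(C(=O)NC(CCCCCC(=O)NO)C(=O)NCc2ccccc2)cc1` — 870 nM

Of the compounds shown here, two have been measured in a functional assay on NFF cells (Homo sapiens) for antiproliferative activity; on this read-out lower numbers stand for stronger inhibition and higher numbers for weaker inhibition. Compound 1 `CN(C)c1ccc(C(=O)N[C@@H](CCCCCC(=O)NO)C(=O)NCc2ccccc2)cc1` gives 12000 nM, and compound 2 `CN(C)c1ccc(C(=O)NC(CCCCCC(=O)NO)C(=O)NCc2ccccc2)cc1` gives 870 nM. Compound 2 therefore holds the lowest of the two numbers, its nearest neighbour being compound 1, with the step of a 14-fold lower number from compound 1 to compound 2 (1.14 log units; beyond the scatter). The only thing separating these two structures is the fact that one of compounds 1 and 2 is drawn with a defined configuration and the other without, at the place where they differ; the benzyl group and the rest of the molecule are identical in both.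

Compound 3 `CN(C)c1ccc(C(=O)NC(CCCCCC(=O)NO)C(=O)NC2CCCc3ccccc32)cc1` is not yet measured. It differs from compound 2 by 1,2,3,4-tetrahydronaphthalen-1-yl in place of benzyl on an amide-type nitrogen. For the measured compounds named here, no measured step touches this part of the molecule: the single step known, a 14-fold lower number from compound 1 to compound 2 (1.14 log units; beyond the scatter), concerns a stereocentre in the chain and not the group on the amide-type nitrogen. There is thus no measured basis for predicting a shift in either direction, and the expected step of a 1.1-fold lower number from compound 2 to compound 3 (0.04 log units; within the scatter) is none beyond the scatter, with wide uncertainty. For compound 3 the estimate in this assay is 800 nM, with a range from 250 nM to 3000 nM.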

Compound 3, half-maximal inhibitory concentration: 1810 nM
For compound 3 the middle estimate is 2.3-fold (0.35 log units) below the measured one; low and high end bracket the measured number.
By their numbers in this assay, from the lowest: compound 2; then compound 3; then compound 1.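

In this assay the group on the amide-type nitrogen proves able to move the read-out: 1,2,3,4-tetrahydronaphthalen-1-yl in place of benzyl gives a 2.1-fold higher number from compound 2 to compound 3 (0.32 log units; beyond the scatter), a modest step, and the earlier pair, which differed only at a stereocentre in the chain, could not show this. The entering group holds 10 carbon atoms against 7 in the leaving one, and neither has a hydrogen-bond donor, a hydrogen-bond acceptor or a net charge, so the larger all-carbon group is accepted on this nitrogen with only a modest step in the weaker direction. Nothing measured in this set bears on why this step occurs.

The compounds shown leave open how this position responds to an amine or a carboxylic acid on the group, or to phenethyl, which has a longer chain, in place of benzyl. Also open, as far as these compounds go, is whether a defined configuration at the chain stereocentre would shift compound 3 as it does in the benzyl pair, where the step is a 14-fold lower number from compound 1 to compound 2 (1.14 log units; beyond the scatter).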